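Replacing the Bicyclic Amide Substituent with an Isobutoxy Group

The source may report more compounds than this note shows. Statements on the series, on what has been measured and on what is new or still open speak of the compounds shown alone.

Compound 2 `Nc1ncnc2c1ncn2C1O[C@H](C(=O)NC2CC3CCC2C3)[C@@H](O)[C@H]1O` stands at the weaker end of the two compounds measured in an assay on cell membranes for binding affinity to 2-oxoglutarate receptor 1 (Rattus norvegicus), read by radioligand binding (on this read-out lower numbers stand for stronger inhibition and higher numbers for weaker inhibition), where compound 2 gives 640 nM. Going by the values given here, its only neighbour in the data is compound 1 `NC(=O)[C@H]1OC(n2cnc3c(N)ncnc32)[C@H](O)[C@@H]1O`, which carries a hydrogen atom on the amide-type nitrogen; in this assay compound 1 gives 64 nM. Among the compounds with values here, the single step in hand, a 10-fold higher number from compound 1 to compound 2 (1.00 log units; beyond the scatter), shows that the bicyclic substituent on that nitrogen cost affinity. Compound 3 `CC(C)CONC(=O)[C@H]1OC(n2cnc3c(N)ncnc32)[C@H](O)[C@@H]1O` differs from compound 2 by a group of 5 heavy atoms (4 carbon, 1 oxygen; no ring) in place of a group of 7 heavy atoms (7 carbon; 2 five-membered non-aromatic rings of carbon only), on an amide-type nitrogen. Because the step of a 10-fold higher number from compound 1 to compound 2 (1.00 log units; beyond the scatter) was the only penalty seen and the entering group has fewer heavy atoms and no ring, the change is expected to recover part, though not necessarily all, of that loss, so a modest step of a 2.6-fold lower number from compound 2 to compound 3 (0.41 log units; beyond the scatter) toward lower numbers is anticipated. Compound 3 is therefore estimated at 250 nM, with a plausible range from 60 nM to 1000 nM.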

Compound 3, inhibition constant: 20 nM
Compound 3: middle estimate off by 13-fold (1.10 log units), on the high side; measured number below the stated range.
By their numbers in this assay, from the lowest: compound 3; then compound 1; then compound 2.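

In this assay a substituent on the amide-type nitrogen no longer reads only as a penalty: isobutoxy in place of hydrogen gives a 3.2-fold lower number from compound 1 to compound 3 (0.51 log units; beyond the scatter) and so takes the number below that of the compound with the amide hydrogen. Isobutoxy in place of the bicyclic group gives a 32-fold lower number from compound 2 to compound 3 (1.51 log units; beyond the scatter) and shows that the identity of the group on this nitrogen sets the direction of the change, not merely whether a group is present. Nothing in hand explains why these two groups part ways at this position.

The compounds shown leave open whether the gain follows the oxygen on the amide-type nitrogen or the branched chain beyond it, which a plain isobutyl group or a methoxy group there could separate. They also leave open how far the trend extends, for instance to a longer chain such as hexyloxy or to a benzyloxy group.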